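Removing the Side-Chain Carboxy of Compound 3

A few compounds are considered here, and "the series" means these few. Any claim that something is new, unique, unknown or untested is made for them only; others in the source may bear on it.

Measured so far:
compound 1, `O=C(O)[C@@H]1CCCN1C(=O)CN(c1nc(Cl)nc2[nH]cnc12)C1CC1` — 34.9%
compound 2, `N=C(N)NCCC[C@H](NC(=O)CN(c1nc(Cl)nc2[nH]cnc12)C1CC1)C(=O)O` — 51%
compound 3, `O=C(O)C[C@H](NC(=O)CN(c1nc(Cl)nc2[nH]cnc12)C1CC1)C(=O)O` — 38.9%

In a functional assay on the whole organism (Tail, strain ICR) with Mus musculus as the target, in the tail flick test, with a stated time of 60 min, at a dose of 25 umol/kg by the oral route (on this read-out higher numbers stand for a stronger effect at the one dose given and lower numbers for a weaker effect), compound 3 stands second highest of the three numbers. Its nearest neighbour is compound 1, a number that lies within the scatter of compound 3; the furthest is compound 2, whose number lies beyond the scatter above it.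

Compound 4, `C[C@H](NC(=O)CN(c1nc(Cl)nc2[nH]cnc12)C1CC1)C(=O)O`, differs from compound 3 by hydrogen in place of carboxy on a saturated chain carbon, two bonds along the chain from an amide-type nitrogen and a carbonyl carbon. Within the data shown here, one measured step touches the same place on the chain: a number 12.1 percentage points lower from compound 2 to compound 3 (beyond the scatter). That step shows that what sits on this saturated chain carbon can move this assay by a modest amount, though the change there went from a larger group to the carboxy rather than from the carboxy to hydrogen. Compound 1, which carries no side chain at this position at all but has a ring instead, gives a number within the scatter of compound 3.

On this basis the step from compound 3 to compound 4 is expected to be small, a number 2.9 percentage points lower from compound 3 to compound 4 (within the scatter), with no direction beyond the scatter asserted. Compound 4 is therefore estimated at 36%, within a range from 24% to 48%.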

Compound 4, a percentage reported as activity, at one dose (the size of the read-out at that dose, not a potency): 44.6%
Estimate against measurement, compound 4: 8.6 percentage points below; low and high end bracket the measured number.
By their numbers in this assay, from the lowest: compounds 1, 3, 4 and 2 (each within the scatter of the next, the first and the last beyond it).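

In this assay, among these compounds, the carboxy on the saturated chain carbon, two bonds along the chain from an amide-type nitrogen and a carbonyl carbon, gives way to hydrogen with a number 5.7 percentage points higher from compound 3 to compound 4 (within the scatter) and so with no step beyond the scatter, which the earlier compounds could not show because none of them carried hydrogen there. Hydrogen also stays within the scatter of the larger group of compound 2, with a number 6.4 percentage points lower from compound 2 to compound 4 (within the scatter), although the step from that group to carboxy, a number 12.1 percentage points lower from compound 2 to compound 3 (beyond the scatter), lies beyond it, so compound 4 cannot be separated from either of two compounds that can be separated from each other, and it is equally unresolved against the ring of compound 1, with a number 9.7 percentage points higher from compound 1 to compound 4 (within the scatter). Nothing at hand accounts for any of these steps.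

The compounds shown leave open whether a longer chain on this carbon, such as an n-butyl group, or a terminal amine, such as 4-aminobutyl, would stand beyond the scatter of hydrogen. They also leave open whether a phenyl ring in that place would do so.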